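Ethyl in Place of Fluoro on a Shared Core

A few compounds are considered here, and "the series" means these few. Any claim that something is new, unique, unknown or untested is made for them only; others in the source may bear on it.

Compound 1 `C=CC(=O)Nc1cccc(NC(=O)CSc2nc(Nc3ccccc3)c3ccccc3n2)c1` gives 7310 nM in a functional assay on MGC-803 cells (Homo sapiens) for inhibition, read by MTT assay, with a stated time of 72 h; on this read-out higher numbers stand for weaker inhibition and lower numbers for stronger inhibition.
Compound 2 `C=CC(=O)Nc1cccc(NC(=O)CSc2nc(Nc3ccc(F)cc3)c3ccccc3n2)c1` gives 8290 nM in this assay.

Among the two measured compounds, compound 2 carries the higher of the two numbers, but its only neighbour is compound 1, and the step between them, a 1.1-fold higher number from compound 1 to compound 2 (0.05 log units; within the scatter), lies within the usual scatter, so the two compounds cannot be told apart on these numbers.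

Compound 3 `C=CC(=O)Nc1cccc(NC(=O)CSc2nc(Nc3ccc(CC)cc3)c3ccccc3n2)c1` has not yet been measured. It differs from compound 2 by ethyl in place of fluoro on an aromatic carbon. For the measured compounds named here, the only measured step that touches the same place is a 1.1-fold higher number from compound 1 to compound 2 (0.05 log units; within the scatter), where fluoro entered in place of hydrogen on that aromatic carbon and the number hardly moved. Going by the values given here, no measured step shows ethyl anywhere on the shared core, so the effect of a two-carbon chain there is unknown, and the one available step gives no reason to expect a change beyond the scatter.

Compound 3 is therefore expected to sit close to compound 2, with a 1.1-fold lower number from compound 2 to compound 3 (0.04 log units; within the scatter) as the estimated step. The estimate for compound 3 is 7500 nM, with a range from 2500 nM to 22000 nM.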

Compound 3, half-maximal inhibitory concentration: 8010 nM
Estimate against measurement, compound 3: 1.1-fold (0.03 log units) below; the range from low to high includes it.
By their numbers in this assay, from the lowest: compounds 1, 3 and 2 (each within the scatter of the next).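

Replacing fluoro with ethyl on this aromatic carbon, para to a large group, gives a 1.0-fold lower number from compound 2 to compound 3 (0.01 log units; within the scatter) in this assay and placing ethyl where compound 1 has hydrogen gives a 1.1-fold higher number from compound 1 to compound 3 (0.04 log units; within the scatter) on the same read-out. Until now, this position had been tested only with the single fluorine atom, whereas these steps show that a group of two carbon atoms can also sit there without a change that rises above the usual scatter, so hydrogen, fluoro and ethyl cannot be told apart at this position on these numbers. No measured evidence is available here to explain this lack of separation.

The compounds shown leave open whether a clearly different group on this carbon, such as an amine, a carboxylic acid or a longer chain like hexyl, would move the number beyond the scatter. They also leave open whether fluoro or ethyl would give a similar result on another carbon of the same ring, which would show whether this flat result belongs to this position alone.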